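Second methoxy on the benzyloxy aryl: outlook for compound 4

The source may hold more compounds than are shown below. What is called first, only, known or untested is meant among the compounds shown, and "the series" means these compounds.

The three measured compounds share one core and differ only in the aryl group of the benzyloxy arm. Compound 1 `Cc1cc(C)cc(COc2ccc(-c3cc(CN4CCN(Cc5ccc(C(F)(F)F)cc5)CC4)no3)cc2)c1` carries a 3,5-dimethylphenyl group; in a functional assay on Huh-7 cells (Homo sapiens) for antiproliferative activity, read by sulforhodamine B assay, with a stated time of 72 h (on this read-out higher numbers stand for weaker inhibition and lower numbers for stronger inhibition), compound 1 gives 600 nM. Compound 2 `N#Cc1cccc(COc2ccc(-c3cc(CN4CCN(Cc5ccc(C(F)(F)F)cc5)CC4)no3)cc2)c1` carries a 3-cyanophenyl group, and in this assay compound 2 gives 100 nM. Compound 3 `COc1cccc(COc2ccc(-c3cc(CN4CCN(Cc5ccc(C(F)(F)F)cc5)CC4)no3)cc2)c1` carries a 3-methoxyphenyl group, and in this assay compound 3 gives 800 nM, the highest of the three numbers. Its step from the nitrile, an 8.0-fold higher number from compound 2 to compound 3 (0.90 log units; beyond the scatter), is beyond the scatter, whereas a 1.3-fold higher number from compound 1 to compound 3 (0.12 log units; within the scatter) lies within it.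

Compound 4 `COc1cc(COc2ccc(-c3cc(CN4CCN(Cc5ccc(C(F)(F)F)cc5)CC4)no3)cc2)cc(OC)c1` differs from compound 3 by methoxy in place of hydrogen on an aromatic carbon. Within the data shown here, no measured step adds a second substituent to an aryl ring that already carries one. The step of a 6.0-fold lower number from compound 1 to compound 2 (0.78 log units; beyond the scatter) and the step to compound 3 from compound 2 both concern the nitrile, which is absent here. The nearest comparison is compound 1, whose 3,5-disubstituted ring sits within the scatter of compound 3, so a second methoxy is expected to leave the number close to where compound 3 stands. The expected step is no change at the digits printed from compound 3 to compound 4 (within the scatter), not beyond the scatter. In this assay compound 4 is estimated at 800 nM, with a range from 300 nM to 2500 nM.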

Compound 4, half-maximal inhibitory concentration: 1500 nM
The estimate for compound 4 lay 1.9-fold (0.27 log units) below the measured number; low and high end bracket the measured number.
By their numbers in this assay, from the lowest: compound 2; then compounds 1, 3 and 4 (each within the scatter of the next, the first and the last beyond it).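

In this assay, among these compounds, the first step that adds a substituent to an aryl ring already carrying one is small: a 1.9-fold higher number from compound 3 to compound 4 (0.27 log units; within the scatter) leaves 3-methoxyphenyl and 3,5-dimethoxyphenyl unresolved, so the second methoxy gives no clear change at this position. Among the compounds shown here, with the 3,5-pattern held fixed, however, the identity of the substituents can be read, as a 2.5-fold higher number from compound 1 to compound 4 (0.40 log units; beyond the scatter) separates 3,5-dimethoxyphenyl from 3,5-dimethylphenyl beyond the scatter, even though compound 3 lies within the scatter of both compound 1 and compound 4, and a 15-fold higher number from compound 2 to compound 4 (1.18 log units; beyond the scatter) is the only step in the set graded large, which leaves the 3-cyanophenyl compound clearly apart from the dimethoxy ring. Nothing available bears on why these steps fall as they do.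

Still open, going by these compounds, is whether the low number of compound 2 depends on the nitrile alone, which a 3,5-dicyanophenyl ring or a ring with one nitrile and one methoxy would test. Equally open, on these data alone, is how a primary amine or a carboxylic acid on the same aromatic carbon would read in this assay on this shared core.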